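This account rests on a few compounds, and the source may have more. Where it says the series, first, only, none or still open, it means among the compounds named here.

Compound 1 `CC(C)N(CCN(C(=O)Nc1cccc(F)c1)C1CC[C@]2(c3cccc(C#N)c3)CC2C1)C(C)C` gives 2.1 nM in a functional assay for antagonist activity at melanin-concentrating hormone receptor 1 (Homo sapiens); a higher number here means a weaker inhibitor, a lower number a stronger inhibitor. Compound 2 `CC(C)N(CCN(C(=O)Nc1cccc(C#N)c1)C1CC[C@]2(c3cccc(C#N)c3)CC2C1)C(C)C` gives 7.6 nM in this assay, and compound 3 `CC(C)N(CCN(C(=O)Nc1cc(F)cc(F)c1)C1CC[C@]2(c3cccc(C#N)c3)CC2C1)C(C)C` gives 4.5 nM in this assay. Among these three numbers compound 3 stands second highest, although its gap to compound 2 is within the scatter, while a 2.1-fold higher number from compound 1 to compound 3 (0.33 log units; beyond the scatter) lies beyond it. Compound 4 `CC(C)N(CCN(C(=O)Nc1cc(Cl)nc(Cl)c1)C1CC[C@]2(c3cccc(C#N)c3)CC2C1)C(C)C` has not yet been measured; it differs from compound 3 by 2,6-dichloropyridin-4-yl in place of 3,5-difluorophenyl on an amide-type nitrogen. Among the measured compounds shown here, the steps that bear on this change are those altering the group on the same amide-type nitrogen: a 3.6-fold higher number from compound 1 to compound 2 (0.56 log units; beyond the scatter), a 2.1-fold higher number from compound 1 to compound 3 (0.33 log units; beyond the scatter) and a 1.7-fold lower number from compound 2 to compound 3 (0.23 log units; within the scatter). Each change of that group so far shifted the number only modestly or not beyond the scatter. Compound 4 introduces a greater departure than any of these, so a modest step toward a higher number is expected, as a 1.8-fold higher number from compound 3 to compound 4 (0.25 log units; within the scatter). Compound 4 is therefore estimated at 8 nM, with a range of 3 nM to 25 nM.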

Compound 4, inhibition constant: 2.4 nM
The estimate for compound 4 lay 3.3-fold (0.52 log units) above the measured number; measured number below the stated range.
By their numbers in this assay, from the lowest: compounds 1, 4, 3 and 2 (each within the scatter of the next, the first and the last beyond it).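

In this assay, the first ring on this amide-type nitrogen with a hetero atom and a hydrogen-bond acceptor, 2,6-dichloropyridin-4-yl, gives a 1.9-fold lower number from compound 3 to compound 4 (0.27 log units; within the scatter) and a 1.1-fold higher number from compound 1 to compound 4 (0.06 log units; within the scatter), so compound 4 stands level with both carbon-only rings bearing fluorine. Only the comparison with the nitrile-bearing ring goes beyond the scatter, as a 3.2-fold lower number from compound 2 to compound 4 (0.50 log units; beyond the scatter), which shows that this position accepts the pyridine ring and both chlorines without a loss beyond the scatter against compound 1 or compound 3. No evidence here accounts for these results.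

The compounds shown do not separate the contribution of the ring nitrogen from that of the two chlorines, a question that 3,5-dichlorophenyl and pyridin-4-yl on the same nitrogen would address. On these data alone, how a saturated ring such as cyclohexyl would fare at this position also remains open.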